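A few compounds are considered here, and "the series" means these few. Any claim that something is new, unique, unknown or untested is made for them only; others in the source may bear on it.

Working notes on the series. Compound 1 `c1ccc(-c2nc[nH]n2)c(NCC2=NCCN2)c1` is one of two measured members. In an in vitro functional assay on cells (Fibroblast) for agonist activity at Alpha-1A adrenergic receptor (Homo sapiens) (on this read-out higher numbers stand for an effect only at larger amounts of compound and lower numbers for an effect already at smaller amounts), compound 1 gives 0.794 nM, the lowest of the two numbers recorded. Going by the values given here, the other measured member, compound 2 `CCn1cccc1-c1ccccc1NCC1=NCCN1`, gives 2.51 nM in this assay, a higher number than compound 1 by a margin that lies beyond the usual scatter; no single-point step between these two compounds has been worked out, so their values are simply set side by side.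

The next compound to be measured is compound 3 `Cn1ccnc1-c1ccccc1NCC1=NCCN1`. Relative to compound 1 it carries 1-methyl-1H-imidazol-2-yl in place of 1H-1,2,4-triazol-3-yl on an aromatic carbon; in words, 1-methyl-1H-imidazol-2-yl in place of 1H-1,2,4-triazol-3-yl on an aromatic carbon. The change removes the single hydrogen-bond donor that the leaving ring counted and keeps the count of two acceptors.

With no measured step of this kind in the series, the expectation for compound 3 can only rest on compound 1 and its value 0.794 nM. A modest shift toward a higher number, not far beyond the scatter, is expected, a 2.0-fold higher number from compound 1 to compound 3 (0.30 log units; within the scatter). Compound 3 is therefore estimated at 1.6 nM in this assay, within a range of 0.6 nM to 4.5 nM.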

Compound 3, half-maximal effective concentration: 6.31 nM
The estimate for compound 3 lay 3.9-fold (0.60 log units) below the measured number; measured number above the stated range.
By their numbers in this assay, from the lowest: compound 1; then compound 2; then compound 3.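

In this assay, putting 1-methyl-1H-imidazol-2-yl in place of 1H-1,2,4-triazol-3-yl on this aromatic carbon, ortho to a group of 7 heavy atoms, gives a 7.9-fold higher number from compound 1 to compound 3 (0.90 log units; beyond the scatter); this first measured step shows that the read-out responds to the identity of the five-membered aromatic ring here, even though both rings count the same hydrogen-bond acceptors. The step is a compound change, since the hydrogen-bond donor count, the heavy-atom count and the number of ring hetero atoms all differ together, so this one pair cannot assign the shift to any one of them. Nothing available bears on the reason for the shift.

The compounds shown leave open whether the higher number follows the loss of the hydrogen-bond donor, the added methyl or the change in ring hetero atoms. A 1H-imidazol-2-yl group and a 1-methyl-1H-1,2,4-triazol-3-yl group on the same aromatic carbon would each separate part of this change, while a primary carboxamide there would test whether a five-membered aromatic ring is needed at all.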